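Bromophenyl for nitrophenyl on compound 2

This account rests on a few compounds, and the source may have more. Where it says the series, first, only, none or still open, it means among the compounds named here.

Of the compounds shown here, three have numbers so far in an ADME assay on HEL cells (Homo sapiens) for cytotoxicity; on this read-out lower numbers stand for higher toxicity in this test and higher numbers for lower toxicity in this test. Compound 1 (`O=C(COc1cccc2ccccc12)N/N=C/c1ccc(O)cc1`) gives 60.6 ug/mL and compound 3 (`O=C(COc1cccc2ccccc12)N/N=C/c1cccc(O)c1`) gives 62.7 ug/mL. Compound 2 (`C/C(=N\NC(=O)COc1cccc2ccccc12)c1cccc([N+](=O)[O-])c1`) gives 10.5 ug/mL, the lowest of the three and beyond the scatter from both of the others.

Compound 4 (`C/C(=N\NC(=O)COc1cccc2ccccc12)c1ccccc1Br`) is the next to read. Its change from compound 2 is 2-bromophenyl in place of 3-nitrophenyl on a carbon with a double bond to nitrogen.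

For the measured compounds named here, only one measured step changes a single place, a 1.0-fold higher number from compound 1 to compound 3 (0.01 log units; within the scatter). That step swaps 4-hydroxyphenyl for 3-hydroxyphenyl and stays within the scatter, but it involves neither the 3-nitrophenyl nor the 2-bromophenyl group. Compound 2 differs from compound 1 and compound 3 in more than one place, so its low number cannot be assigned to the 3-nitrophenyl group alone. Compound 4 keeps the saturated chain carbon of compound 2, which makes 10.5 ug/mL the best anchor. With no measured evidence for a direction, the expected result in this assay is a 1.1-fold higher number from compound 2 to compound 4 (0.06 log units; within the scatter), with no move beyond the scatter anticipated. For compound 4 the estimate is 12 ug/mL, with an expected range of 4 ug/mL to 45 ug/mL.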

Compound 4, half-maximal cytotoxic concentration: 16.2 ug/mL
Beside the measured number, compound 4's estimate is 1.4-fold (0.13 log units) below it; measured number inside the range.
By their numbers in this assay, from the lowest: compounds 2 and 4 (each within the scatter of the next); then compounds 1 and 3 (each within the scatter of the next).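

In this assay, for the compounds shown here, the exchange on a carbon with a double bond to nitrogen, whose other neighbours are the double-bonded nitrogen and a saturated chain carbon, gives a 1.5-fold higher number from compound 2 to compound 4 (0.19 log units; within the scatter) and is the first single-place step read at this position with the saturated chain carbon present. The number of compound 2 therefore does not depend on 3-nitrophenyl as opposed to 2-bromophenyl: the step replaces 9 heavy atoms with 7 and 2 hydrogen-bond acceptors with 0 without a move beyond the scatter, so this position accepts two quite different substituted phenyl groups with no readable change. No measured property of either group bears on this step, so the result carries no explanation.

As far as these compounds go, the step changes both the substituent and its place on the phenyl ring, so the contribution of each stays unseparated, and it remains open whether a very different group, such as an amine or a carboxylic acid on that ring, would hold the number. A 3-hydroxyphenyl group on this same carbon with the saturated chain carbon would link compound 2 and compound 4 to compound 3 through single-place steps.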